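The source may hold more compounds than are shown below. What is called first, only, known or untested is meant among the compounds shown, and "the series" means these compounds.

Notes on the series. Compound 1 `O=C1/C(=C\c2ccc(F)cc2)c2ccccc2N1c1c(Cl)cccc1Cl`, compound 2 `O=C1/C(=C\c2ccccc2Cl)c2ccccc2N1c1c(Cl)cccc1Cl` and compound 3 `COc1ccc(/C=C2\C(=O)N(c3c(Cl)cccc3Cl)c3ccccc32)cc1` share one core and differ only in the aryl group on the double-bonded chain carbon. In a functional assay on MOLT-4 cells (Homo sapiens) for cytotoxicity, read by MTT assay, with a stated time of 72 h (a higher number here means that more compound is needed for the effect, a lower number that less compound is needed), compound 2 gives 7 ug/mL. Compound 1 gives "not determined" (no result reported) and compound 3 gives "not determined" (no result reported), so compound 3 stands without a single number in this assay, as does one further member, compound 1. Compound 4 `O=C1/C(=C\c2ccccc2[N+](=O)[O-])c2ccccc2N1c1c(Cl)cccc1Cl` follows from compound 3 by 2-nitrophenyl in place of 4-methoxyphenyl on a double-bonded chain carbon bound to a double-bonded ring carbon. With no number for compound 3, the size and direction of the step to compound 4 in this assay cannot be gauged from that pair; the expectation rests instead on compound 2, whose value 7 ug/mL shows what this core delivers with a substituted phenyl in the same place. Compound 4 is therefore expected near 7 ug/mL, within 2.5 ug/mL to 20 ug/mL.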

Compound 4, concentration for half-maximal effect: 6 ug/mL
Compound 4: middle estimate off by 1.2-fold (0.07 log units), on the high side, and the stated range covers the measured number.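

Nitro in place of chloro on an aromatic carbon gives a 1.2-fold lower number from compound 2 to compound 4 (0.07 log units; within the scatter) in this assay, so a second substituted phenyl at this place now has a number, and the two numbers cannot be told apart. Steps to compound 1 and compound 3 cannot be read. No measurement on hand accounts for this result.

As far as these compounds go, whether the place tolerates every group thus stays open, since only compound 2 and compound 4 carry numbers. From the compounds shown here alone, how an amine or a carboxylic acid on the aryl group would shift the number also remains open.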